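This account rests on a few compounds, and the source may have more. Where it says the series, first, only, none or still open, it means among the compounds named here.

Measured compounds:
compound 1, `Cc1nn(-c2nc(-c3ccc(Cl)c(Cl)c3)c(SC(C)C)s2)c(C(=O)O)c1-c1ccccc1`, 3000 nM
compound 2, `Cc1ccccc1-c1c(C)nn(-c2nc(-c3ccc(Cl)c(Cl)c3)c(SC(C)C)s2)c1C(=O)O`, 5500 nM
compound 3, `COc1cc(-c2c(C)nn(-c3nc(-c4ccc(Cl)c(Cl)c4)c(SC(C)C)s3)c2C(=O)O)cc(C(F)(F)F)c1`, 1380 nM

In a functional assay on BJAB cells (Homo sapiens) for antiproliferative activity, with a stated time of 4 days (a higher number here means that more compound is needed for the effect, a lower number that less compound is needed), compound 3 gives the lowest of the three numbers; the nearest is compound 1, the furthest compound 2. Compound 4, `Cc1nn(-c2nc(-c3ccc(Cl)c(Cl)c3)c(SC(C)C)s2)c(C(=O)O)c1-c1ccc(Cl)cc1`, has not yet been measured. It differs from compound 3 in one place: 4-chlorophenyl in place of 3-methoxy-5-(trifluoromethyl)phenyl on an aromatic carbon. Within the data shown here, no measured step changes the phenyl ring in the same way. Among the measured compounds shown here, the steps that bear on this position are a 2.2-fold lower number from compound 1 to compound 3 (0.34 log units; beyond the scatter) and a 4.0-fold lower number from compound 2 to compound 3 (0.60 log units; beyond the scatter), both modest, while a 1.8-fold higher number from compound 1 to compound 2 (0.26 log units; within the scatter) lies within the scatter. A return to a more lightly substituted ring is therefore expected to move the number back towards that of compound 1, giving for compound 4 an estimated 2200 nM, between 900 nM and 5500 nM, a step of a 1.6-fold higher number from compound 3 to compound 4 (0.20 log units; within the scatter).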

Compound 4, half-maximal effective concentration: 2500 nM
The estimate for compound 4 lay 1.1-fold (0.06 log units) below the measured number; the range from low to high includes it.
By their numbers in this assay, from the lowest: compounds 3, 4, 1 and 2 (each within the scatter of the next, the first and the last beyond it).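

In this assay, a single chloro on the phenyl ring makes no clear difference: a 1.2-fold lower number from compound 1 to compound 4 (0.08 log units; within the scatter) stays within the scatter. Exchanging the larger substituted ring for 4-chlorophenyl is also unresolved, with a 1.8-fold higher number from compound 3 to compound 4 (0.26 log units; within the scatter) within the scatter too, so these two rings cannot be told apart here. Only 2-methylphenyl separates from 4-chlorophenyl, through a 2.2-fold lower number from compound 2 to compound 4 (0.34 log units; beyond the scatter) as a modest step.

From the compounds shown here alone, whether an amine or a nitrile on this phenyl ring would move the number further remains open. Nothing measured here accounts for these steps.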